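This account rests on a few compounds, and the source may have more. Where it says the series, first, only, none or still open, it means among the compounds named here.

Compound 3 `COC(=O)[C@@]1(C)CCC=C2[C@@H]1CC[C@@H](C)[C@]2(C)Cc1c[nH]c2ccc(F)cc12` gives 4800 nM in a functional assay on HBL-100 cells (Homo sapiens) for inhibition, read by sulforhodamine B assay, with a stated time of 48 h; a lower number here means a stronger inhibitor of growth, a higher number a weaker inhibitor of growth. Among the three compounds measured, it stands second highest: compound 1 `COC(=O)[C@@]1(C)CCC=C2[C@@H]1CC[C@@H](C)[C@]2(C)Cc1c[nH]c2ccccc12` gives 4500 nM, and the step of a 1.1-fold higher number from compound 1 to compound 3 (0.03 log units; within the scatter) lies within the scatter, while compound 2 `COC(=O)[C@@]1(C)CCC=C2[C@@H]1CC[C@@H](C)[C@]2(C)Cc1c[nH]c2ccc(C)cc12` gives 18000 nM, and the step of a 3.8-fold lower number from compound 2 to compound 3 (0.57 log units; beyond the scatter) lies beyond it. Compound 4 `COC(=O)[C@@]1(C)CCC=C2[C@@H]1CC[C@@H](C)[C@]2(C)Cc1c[nH]c2ccc(OC)cc12` differs from compound 3 by methoxy in place of fluoro on an aromatic carbon. Among the measured compounds shown here, two measured steps bear on substitution at this position. The step of a 1.1-fold higher number from compound 1 to compound 3 (0.03 log units; within the scatter) shows that fluoro there changes nothing beyond the scatter, whereas the step of a 4.0-fold higher number from compound 1 to compound 2 (0.60 log units; beyond the scatter) shows that methyl there raises the number modestly. Because the step of a 4.0-fold higher number from compound 1 to compound 2 (0.60 log units; beyond the scatter) is the one in which a carbon-bearing group enters, it is taken as the closer guide for methoxy, and a modest rise in this assay is expected rather than none. The estimate for compound 4 is therefore 9000 nM, with a range from 3500 nM to 25000 nM, which would mean an expected step of a 1.9-fold higher number from compound 3 to compound 4 (0.27 log units; within the scatter).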

Compound 4, concentration for 50% growth inhibition: 2100 nM
Compound 4: the middle estimate sits 4.3-fold (0.63 log units) above what was measured, and the stated range ends above it.
By their numbers in this assay, from the lowest: compound 4; then compounds 1 and 3 (each within the scatter of the next); then compound 2.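

In this assay, this position, meta to a fused ring and para to a fused ring, proves able to move the number down as well as up: methoxy in place of hydrogen gives a 2.1-fold lower number from compound 1 to compound 4 (0.33 log units; beyond the scatter), whereas fluoro left it within the scatter and methyl raised it. The entry of carbon at this position therefore does not by itself raise the number, for methoxy in place of methyl gives an 8.6-fold lower number from compound 2 to compound 4 (0.93 log units; beyond the scatter). The change from fluoro to methoxy also lies beyond the scatter, at a 2.3-fold lower number from compound 3 to compound 4 (0.36 log units; beyond the scatter), so these two groups are not interchangeable here.

Nothing shown gives a reason for these differences. From the compounds shown here alone, whether a hydroxyl group, an amine or ethoxy at this position would lower the number further or raise it stays open, as does the effect of methoxy elsewhere on the ring.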